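From 3,5-dichlorobenzyl to 4-chlorobenzyl

The source may hold more compounds than are shown below. What is called first, only, known or untested is meant among the compounds shown, and "the series" means these compounds.

In a functional assay on U-937 cells (Homo sapiens) for inhibition, read by sulforhodamine B assay, with a stated time of 72 h (a higher number here means a weaker inhibitor of growth, a lower number a stronger inhibitor of growth), compound 1 `O=C(NO)c1cnc(N2C[C@H]3CN(C(=O)c4ccc5ccccc5c4)C[C@H]3C2)nc1` reads 390 nM and compound 2 `COc1ccc2c(ccn2N2C[C@H]3CN(c4ncc(C(=O)NO)cn4)C[C@H]3C2)c1` reads 390 nM while compound 3 `O=C(NO)c1cnc(N2C[C@H]3CN(Cc4cc(Cl)cc(Cl)c4)C[C@H]3C2)nc1` reads 300 nM in the same test. The three compounds carry different groups on the shared core, and compound 3 stands level with the other two, its number lying within the scatter of both.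

Compound 4 `O=C(NO)c1cnc(N2C[C@H]3CN(Cc4ccc(Cl)cc4)C[C@H]3C2)nc1` differs from compound 3 in one place only, and the change 4-chlorophenyl in place of 3,5-dichlorophenyl on a saturated chain carbon bound to an amine nitrogen in a ring turns 3,5-dichlorobenzyl into 4-chlorobenzyl. Among the measured compounds shown here, no measured pair isolates a change of this kind, so the data give no direct guide to it. Compound 2 at 390 nM and compound 3 at 300 nM bear very different groups and still sit within the scatter of each other, so no step beyond the scatter is expected in this assay here. The expected step of a 1.2-fold higher number from compound 3 to compound 4 (0.07 log units; within the scatter) is small and within the scatter. For compound 4 the estimate is 350 nM with 130 nM to 900 nM as the expected range.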

Compound 4, concentration for 50% growth inhibition: 230 nM
Compound 4: middle estimate off by 1.5-fold (0.18 log units), on the high side; low and high end bracket the measured number.
By their numbers in this assay, from the lowest: compounds 4, 3, 1 and 2 (each within the scatter of the next).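

Among the compounds shown here, the step of a 1.3-fold lower number from compound 3 to compound 4 (0.12 log units; within the scatter), read in this assay, is the first direct comparison at this position, on a saturated chain carbon bound to an amine nitrogen in a ring. It shows that 3,5-dichlorobenzyl and 4-chlorobenzyl cannot be told apart here, so in this one pair a single chlorine on the phenyl ring serves as well as two, with no step beyond the scatter. Nothing at hand accounts for this result.

The compounds shown leave open whether any chlorine is needed at all, a question that an unsubstituted benzyl group would address, and whether a more distinct substituent, such as a carboxylic acid on the phenyl ring, would move the number beyond the scatter. They also leave open how a longer chain, such as phenethyl in place of benzyl, would read.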